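A Methyl-to-Ethyl Change Measured Once, Expected Again

The source may report more compounds than this note shows. Statements on the series, on what has been measured and on what is new or still open speak of the compounds shown alone.

Compound 1 `COc1ccc(-c2noc(-c3ccc(OC)cc3)c2C)cc1` gives > 100000 nM in an ADME assay on HMEC-1 cells (Homo sapiens) for antiproliferative activity, read by cell counting, with a stated time of 5 days (a lower number here means a stronger inhibitor, a higher number a weaker inhibitor), which is a limit of the assay and not a number.
Compound 2 `CCc1c(-c2ccc(OC)cc2)noc1-c1ccc(OC)cc1` gives > 100000 nM in this assay, also a limit of the assay.
Among the compounds with values here, compound 3 `Cc1c(-c2ccc(O)cc2)noc1-c1ccc(O)cc1` gives 47000 nM in this assay, the only number among the three.

Compound 1 and compound 2 differ by methyl in place of hydrogen on a saturated chain carbon bound to an aromatic carbon. The step that the two limits leave unreadable from compound 1 to compound 2 cannot be sized, because the limit of > 100000 nM in this assay, at which 2 of the 3 values shown sit, hides where each of the two truly lies. The cores of compound 1 and compound 3 differ in more than one place; that difference is not broken down here.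

Compound 4 `CCc1c(-c2ccc(O)cc2)noc1-c1ccc(O)cc1` has not been measured. It differs from compound 3 by methyl in place of hydrogen on a saturated chain carbon bound to an aromatic carbon, the same change as from compound 1 to compound 2, at the same place. Since the measured example of this change is unreadable, nothing shows the change moving potency, and compound 3 is the only numbered anchor. Compound 4 is therefore expected to stay close to compound 3, a step of about a 1.1-fold higher number from compound 3 to compound 4 (0.03 log units; within the scatter). The estimate for compound 4 in this assay is 50000 nM, expected to fall between 15000 nM and 150000 nM.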

Compound 4, half-maximal inhibitory concentration: 9700 nM
The estimate for compound 4 lay 5.2-fold (0.71 log units) above the measured number; the whole stated range lies above it.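

In this assay, the change from methyl to ethyl gives a 4.8-fold lower number from compound 3 to compound 4 (0.69 log units; beyond the scatter), a modest but real gain in potency on the core of compound 3. The same change on the core of compound 1 cannot be read, because both of its values are limits of the assay and not numbers: the limit of > 100000 nM in this assay, at which 2 of the 4 values shown sit. This leaves one readable example of the change, on one core only, so it neither shows that the gain carries over to the other core nor shows that it fails to.

The compounds shown leave open whether a longer chain, such as propyl, would lower the number further on the core of compound 3, or whether the gain stops at ethyl. They also leave open whether an amine or a carboxylic acid at the end of that chain would keep the potency of compound 4.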